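The source may report more compounds than this note shows. Statements on the series, on what has been measured and on what is new or still open speak of the compounds shown alone.

Compound 1 `OC[C@@H]1CCCC[C@@H]1N1C=NC2C(Cl)=NC=NC21` is a fused two-ring core carrying a chloro group and a side chain ending in a hydroxymethyl. In a functional assay on HeLa cells (Homo sapiens) for cytotoxicity (a lower number here means that less compound is tolerated, a higher number that more compound is tolerated), compound 1 gives 400 ug/mL. Its nearest measured neighbour is compound 2 `NC1=NC=NC2C1N=CN2[C@H]1CCCC[C@H]1CO`, which in this assay gives 400 ug/mL, so compound 1 stands level with compound 2 within the scatter, with no change at the digits printed from compound 1 to compound 2 (within the scatter).

Compound 3 `NC1=NC2C(N=CN2[C@H]2CCCC[C@H]2CO)C(Cl)=N1` keeps the chloro group of compound 1 and differs from it by amino in place of hydrogen on a carbon with a double bond to nitrogen, the new group sitting between two ring nitrogen atoms.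

For the measured compounds named here, the only measured step, no change at the digits printed from compound 1 to compound 2 (within the scatter), also brought in an amino group and left tolerance unchanged, so no shift beyond the scatter is expected here. For compound 3 the expected value in this assay is 400 ug/mL, with a range of 200 ug/mL to 800 ug/mL, an expected step of no change at the digits printed from compound 1 to compound 3 (within the scatter).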

Compound 3, minimum cytotoxic concentration: > 200 ug/mL
Compound 3 was reported as a limit; the forecaster's own chance of this, stated with the estimate: 20%; the middle value lies beyond the limit too.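

Compound 3 gives > 200 ug/mL as a limit and not a number, so the step from compound 1 to compound 3 cannot be read. The compounds shown leave open whether amino in place of hydrogen changes how much compound is tolerated.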